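The source may hold more compounds than are shown below. What is called first, only, known or untested is meant among the compounds shown, and "the series" means these compounds.

Compound 1 `Cc1ccc(C)c(-c2nc(CN3CCC(C(=O)NCCCN4C[C@H](C)C[C@H](C)C4)CC3)c(C)o2)c1` is the starting point of this account. In a physicochemical assay for permeability, using PAMPA (on this read-out lower numbers stand for lower permeability and higher numbers for higher permeability), compound 1 gives "not determined" (no result reported); its permeability was not determined, so there is no number on which it can be placed. The same series holds compound 2 `Cc1ccccc1-c1nc(CN2CCC(C(=O)NCCCN3CCC(C(C)C)CC3)CC2)c(C)o1`, which in this assay gives 396 10^-6 cm/s, and compound 3 `Cc1ccccc1-c1nc(CN2CCC(C(=O)NCCCN3CC4CCCC(C4)C3)CC2)c(C)o1`, which in this assay gives 331 10^-6 cm/s.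

The step from compound 1 to compound 4 `Cc1ccc(-c2nc(CN3CCC(C(=O)NCCCN4C[C@H](C)C[C@H](C)C4)CC3)c(C)o2)cc1C` is a rearrangement of the same atoms: 3,4-dimethylphenyl in place of 2,5-dimethylphenyl on an aromatic carbon. The change sits on the aryl end of the shared core and leaves the rest of the molecule untouched.

For the measured compounds named here, only one measured step exists in this set, a 1.2-fold lower number from compound 2 to compound 3 (0.08 log units; within the scatter), and it concerns the amine at the far end of the chain rather than the aryl group, so it bears on the present change only as a general indication that a swap of one saturated group for another of the same size left the read-out where it was. Going by the values given here, no measured step touches the dimethylphenyl group itself. On that footing no move beyond the scatter is expected from compound 1 to compound 4, and the two measured neighbours suggest the level. Compound 4 is therefore estimated to give about 350 10^-6 cm/s in this assay, within a range from 200 10^-6 cm/s to 600 10^-6 cm/s.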

Compound 4, apparent permeability: 219 10^-6 cm/s
Beside the measured number, compound 4's estimate is 1.6-fold (0.20 log units) above it; the range from low to high includes it.
By their numbers in this assay, from the lowest: compounds 4, 3 and 2 (each within the scatter of the next).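

Compound 1 has no number in this assay, so the step from compound 1 to compound 4 cannot be read. The compounds shown leave open what 3,4-dimethylphenyl in place of 2,5-dimethylphenyl does to this read-out. Nothing at hand offers an explanation for the value of compound 4.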